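The compounds below may be only part of what the source reports. "The series", "measured", "known", "first", "only" and "open" are said of these compounds alone.

In an ADME assay on HEK293 cells (Homo sapiens) for cytotoxicity, read by MTT assay, with a stated time of 48 h (on this read-out higher numbers stand for weaker inhibition and lower numbers for stronger inhibition), compound 1 `COc1cc(NC(=O)c2cc(C(F)(F)F)cc(C(F)(F)F)c2)ccc1NS(C)(=O)=O` gives 42000 nM. Compound 2 `CS(=O)(=O)Nc1ccc(NC(=O)c2cccc(C(F)(F)F)c2)cc1F` reaches only the limit of the assay, > 250000 nM, so no number is known for it. This is the limit of > 250000 nM in this assay, at which 1 of the 2 values shown sits. Compound 3 `CS(=O)(=O)Nc1ccc(NC(=O)c2cc(C(F)(F)F)cc(C(F)(F)F)c2)cc1F` has not yet been tested. Compound 3 differs from compound 2 by trifluoromethyl in place of hydrogen on an aromatic carbon. Within the data shown here, no measured step of this kind is available, so the direction is uncertain, though compound 1, which also carries the entering trifluoromethyl group, gives 42000 nM in this assay. Compound 3 is expected to give about 100000 nM in this assay, between 35000 nM and 300000 nM. That would mean an expected step of an at least 2.5-fold lower number from compound 2 to compound 3 (0.39 log units; beyond the scatter).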

Compound 3, half-maximal inhibitory concentration: > 250000 nM
Compound 3: no number, only a limit; the forecaster's own chance of this, stated with the estimate: 40%; middle value at least 2.5-fold (0.39 log units) from the limit.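

Trifluoromethyl in place of hydrogen does not bring the compound within range in this assay: compound 3, like compound 2, gives only a limit, so the step between them cannot be read. Among these compounds, the one readable step is an at least 5.9-fold higher number from compound 1 to compound 3 (0.77 log units; beyond the scatter), with fluoro in place of methoxy, so a number appears here only with methoxy on that carbon. The two fluoro compounds cannot be told apart: the limit of > 250000 nM in this assay, at which 2 of the 3 values shown sit.

On these data alone, whether an amine or a longer ether chain in place of fluoro would also give a measurable number stays open. As far as these compounds go, how compound 2 and compound 3 truly compare also stays open.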